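Adding a Bromo Group to Compound 2

The compounds below may be only part of what the source reports. "The series", "measured", "known", "first", "only" and "open" are said of these compounds alone.

Compound 1 `Cc1noc(NS(=O)(=O)c2ccc(NC(=O)c3cc4ccc(O)cc4oc3=O)cc2)c1C`: 16200 nM
Compound 2 `Cc1noc(NS(=O)(=O)c2ccc(NC(=O)c3cc4ccccc4oc3=O)cc2)c1C`: 19900 nM

In a functional assay on PANC-1 cells (Homo sapiens) for antiproliferative activity, read by fluorescence and resazurin assay, with a stated time of 48 h (on this read-out lower numbers stand for stronger inhibition and higher numbers for weaker inhibition), compound 2 gives 19900 nM and compound 1 gives 16200 nM, so these two values lie within the scatter of each other. Compound 3 `Cc1noc(NS(=O)(=O)c2ccc(NC(=O)c3cc4cc(Br)ccc4oc3=O)cc2)c1C` differs from compound 2 in one place: bromo in place of hydrogen on an aromatic carbon. Among the measured compounds shown here, only one measured step offers any guide: a 1.2-fold higher number from compound 1 to compound 2 (0.09 log units; within the scatter). That step involves hydroxy rather than bromo, so it bears on the new change only loosely. For the measured compounds named here, no measured compound carries bromo, so the data point in no direction, and no step beyond the scatter is expected in this assay. The estimated change is a 1.2-fold lower number from compound 2 to compound 3 (0.09 log units; within the scatter). Compound 3 is expected at 16000 nM, with an estimated range of 7000 nM to 35000 nM.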

Compound 3, half-maximal inhibitory concentration: 28700 nM
For compound 3 the middle estimate is 1.8-fold (0.25 log units) below the measured one; the range from low to high includes it.
By their numbers in this assay, from the lowest: compounds 1, 2 and 3 (each within the scatter of the next).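

In this assay, a bromo group on this aromatic carbon gives a 1.4-fold higher number from compound 2 to compound 3 (0.16 log units; within the scatter), so at this place the assay does not separate bromo from hydrogen. Among the compounds shown here, this is the first halogen, and it shows that adding this one heavy atom to the six-membered aromatic ring of carbon only does not move the number beyond the usual scatter, as was also true of the hydroxy step on that ring. The data shown offer no measurement that could explain this result.

From the compounds shown here alone, whether an amine, a carboxylic acid or a longer chain on this same carbon would move the number beyond the scatter stays open. Going by these compounds, it is also open whether bromo would behave the same way on the other carbons of this ring.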